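Vinyl sulfone series on colon carcinoma cells: acetyl to cyano

The source may report more compounds than this note shows. Statements on the series, on what has been measured and on what is new or still open speak of the compounds shown alone.

Measured compounds:
compound 1 `CCOC(=O)C(=Cc1c(-c2ccccc2)[nH]c2ccccc12)C(=O)OCC` gives 4600 nM
compound 2 `CC(=O)/C(=C\c1c(-c2ccccc2)[nH]c2ccccc12)S(=O)(=O)c1ccccc1` gives 589 nM
compound 3 `COc1ccc2[nH]c(-c3ccccc3)c(C=C(C#N)C#N)c2c1` gives 3100 nM

In a functional assay on HT-29 cells (Homo sapiens) for inhibition, read by sulforhodamine B assay, with a stated time of 48 h (a higher number here means a weaker inhibitor of growth, a lower number a stronger inhibitor of growth), compound 2 has the lowest number of the three, and its gaps to compound 3 and to compound 1 both lie beyond the scatter, so on these numbers it is the strongest growth inhibitor of the set. Compound 3, with a dicyano chain on a core bearing a methoxy group, and compound 1, with a diester chain, sit higher.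

The next compound, compound 4 `N#C/C(=C\c1c(-c2ccccc2)[nH]c2ccccc12)S(=O)(=O)c1ccccc1`, keeps the sulfonyl chain of compound 2 and differs in one place: cyano in place of acetyl on a double-bonded chain carbon bound to a double-bonded chain carbon and a sulfonyl sulfur

For the measured compounds named here, no step between two measured compounds matches this change, so there is nothing to scale it. Compound 3 shows that a cyano-bearing chain can carry activity in this assay, though its number is higher than that of compound 2. The expectation for compound 4 is a step of a 1.5-fold higher number from compound 2 to compound 4 (0.18 log units; within the scatter), close to none beyond the scatter, with a modest loss as the more likely direction. Compound 4 is thus estimated at 900 nM, in the range 300 nM to 2700 nM.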

Compound 4, concentration for 50% growth inhibition: 595 nM
The estimate for compound 4 lay 1.5-fold (0.18 log units) above the measured number, and the stated range covers the measured number.
By their numbers in this assay, from the lowest: compounds 2 and 4 (each within the scatter of the next); then compounds 3 and 1 (each within the scatter of the next).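

In this assay, cyano in place of acetyl on a double-bonded chain carbon bound to a double-bonded chain carbon and a sulfonyl sulfur gives a 1.0-fold higher number from compound 2 to compound 4 (0.00 log units; within the scatter), so the two groups cannot be told apart at this position. For the compounds shown here, until now, no step had tested this place; this pair shows that, with the sulfonyl chain kept, growth inhibition in this assay does not depend on the acetyl group. Nothing at hand accounts for the two groups reading alike.

As far as these compounds go, whether this tolerance extends beyond these two groups remains open, for instance to a carboxylic acid, a primary amide or a longer acyl chain. Also open, from the compounds shown here alone, is whether the match between acetyl and cyano holds on a core carrying a methoxy group.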